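The compounds below may be only part of what the source reports. "The series", "measured", "known", "first", "only" and "open" are said of these compounds alone.

Measured in a functional assay on SK-BR-3 cells (Homo sapiens) for antiproliferative activity; a higher number here means a weaker inhibitor, a lower number a stronger inhibitor:
- compound 1 `CC(C)=CCc1cc(C(=O)Nc2cc3ccc(OCCC4CCCCN4)c(C)c3oc2=O)ccc1O`: 640 nM
- compound 2 `CCNCCCOc1ccc2cc(NC(=O)c3ccc(O)c(CC=C(C)C)c3)c(=O)oc2c1C`: 720 nM
- compound 3 `CC(C)=CCc1cc(C(=O)Nc2cc3ccc(OCCCNCC(C)C)c(C)c3oc2=O)ccc1O`: 1030 nM

These three compounds share one core and differ only in the amine group carried on the chain. Compound 3, at 1030 nM, lies within the usual scatter of both other compounds, so the three cannot be ranked.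

The next compound, compound 4 `CC(C)=CCc1cc(C(=O)Nc2cc3ccc(OCCCN(C)C(C)(C)C)c(C)c3oc2=O)ccc1O`, differs from compound 3 in one place: methyl(tert-butyl)amino in place of isobutylamino on a saturated chain carbon, three bonds along the chain from an oxygen on an aromatic ring. In words, methyl(tert-butyl)amino stands in place of isobutylamino on a saturated chain carbon, three bonds along the chain from an oxygen on an aromatic ring.

Among the compounds with values here, three measured steps bear on this change, since each alters the amine group. They are a 1.1-fold higher number from compound 1 to compound 2 (0.05 log units; within the scatter), a 1.6-fold higher number from compound 1 to compound 3 (0.21 log units; within the scatter) and a 1.4-fold higher number from compound 2 to compound 3 (0.16 log units; within the scatter). All three stay within the scatter, so among these compounds, changing the amine group has not moved the number measurably. As far as these compounds go, none of them carries methyl(tert-butyl)amino, however, so the new group is untested and the range must stay wide.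

No step beyond the scatter is therefore expected in this assay, and the estimated step is a 1.0-fold lower number from compound 3 to compound 4 (0.01 log units; within the scatter). Compound 4 is expected at about 1000 nM, with an estimated range from 400 nM to 2500 nM.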

Compound 4, half-maximal inhibitory concentration: 880 nM
Beside the measured number, compound 4's estimate is 1.1-fold (0.06 log units) above it, and the stated range covers the measured number.
By their numbers in this assay, from the lowest: compounds 1, 2, 4 and 3 (each within the scatter of the next).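

In this assay, methyl(tert-butyl)amino in place of isobutylamino gives (a 1.2-fold lower number from compound 3 to compound 4 (0.07 log units; within the scatter)), and the steps from the other two compounds, (a 1.2-fold higher number from compound 2 to compound 4 (0.09 log units; within the scatter)) and (a 1.4-fold higher number from compound 1 to compound 4 (0.14 log units; within the scatter)), also stay within the scatter. What is new is the kind of amine: unlike the amine groups of compounds 1, 2 and 3, this group has no hydrogen on its nitrogen, going from 1 hydrogen-bond donor in isobutylamino to 0 hydrogen-bond donors, and it still shows no measurable shift, so among these four compounds a hydrogen on this nitrogen makes no measurable difference to the number. No supporting measurement is available to explain this flat result.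

All four groups shown at the end of the chain are amines, so it remains open whether the number would hold with a carboxylic acid or a simple alcohol there instead. As far as these compounds go, a longer chain, such as a 5-(isobutylamino)pentyl group, also remains open, as does whether an amine is needed at this position at all.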